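From 3-chlorophenyl to 4-fluorophenyl at the assay limit

This account rests on a few compounds, and the source may have more. Where it says the series, first, only, none or still open, it means among the compounds named here.

Compound 3 `Clc1cccc(Cn2cnc3c(-c4ccco4)nc(Cl)nc32)c1` was tested in a functional assay on Vero cells (Chlorocebus sabaeus) for inhibition; a higher number here means a weaker inhibitor, a lower number a stronger inhibitor. Compound 3 gives > 10 ug/mL, which is a limit and not a number. Compound 2 `Clc1nc(-c2ccco2)c2ncn(Cc3ccc(Cl)c(Cl)c3)c2n1` gives > 10 ug/mL, also a limit. Compound 1 `Fc1ccc(Cn2cnc3c(-c4ccco4)ncnc32)cc1` gives > 10 ug/mL, again a limit. Among the measured compounds shown here, every compound tested so far therefore sits together: the limit of > 10 ug/mL in this assay, at which 3 of the 3 values shown sit.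

Compound 4 `Fc1ccc(Cn2cnc3c(-c4ccco4)nc(Cl)nc32)cc1` has 4-fluorophenyl in place of 3-chlorophenyl on a saturated chain carbon bound to an aromatic nitrogen. For the measured compounds named here, the only measured step that changes one place is a step that the two limits leave unreadable from compound 2 to compound 3. It concerns a different place and provides no size to carry over. Compound 1 also carries 4-fluorophenyl, but its limit likewise gives no number.

With no readable step to draw on, no step beyond the scatter is expected in this assay, and the estimated change is a step that the limit leaves unreadable from compound 3 to compound 4. Compound 4 is estimated at 15 ug/mL, with an expected range from 7 ug/mL to 40 ug/mL. The assay will probably report only a limit again.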

Compound 4, half-maximal inhibitory concentration: 11.5 ug/mL
Beside the measured number, compound 4's estimate is 1.3-fold (0.12 log units) above it; the measured number falls inside the stated range.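

Compound 4 now gives a real number in this assay, yet no step from compound 1, compound 2 or compound 3 to it can be read, because those three give only a limit: the limit of > 10 ug/mL in this assay, at which 3 of the 4 values shown sit.

As far as these compounds go, the size of each change, including 4-fluorophenyl in place of 3-chlorophenyl, stays open.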